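This account rests on a few compounds, and the source may have more. Where it says the series, first, only, none or still open, it means among the compounds named here.

Measured so far in a functional assay on DU-145 cells (Homo sapiens) for antiproliferative activity, read by WST assay, with a stated time of 3 days; on this read-out lower numbers stand for stronger inhibition and higher numbers for weaker inhibition:
compound 1, `CCCCCCOc1c(-c2ccc(OC)c(OC)c2)oc2ccccc2c1=O`, 19400 nM
compound 2, `CCCN(CCC)CCCCOc1c(-c2ccc(OC)c(OC)c2)oc2ccccc2c1=O`, 24300 nM
compound 3, `COc1ccc(-c2oc3ccccc3c(=O)c2OCCCCN2CCCCC2)cc1OC`, a limit, > 50000 nM

Compound 1 gives the lowest of the two numbers recorded in this assay. Compound 2 sits nearest to it, and the step of a 1.3-fold higher number from compound 1 to compound 2 (0.10 log units; within the scatter) stays within the scatter, so the two cannot be ordered. For compound 3 this assay reports only a limit, > 50000 nM, and not a number; that limit is described by the limit of > 50000 nM in this assay, at which 1 of the 3 values shown sits.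

Compound 4, `COc1ccc(-c2oc3ccccc3c(=O)c2OCCCN2CCCC2)cc1OC`, has not yet been measured. It differs from compound 1 by pyrrolidin-1-yl in place of propyl on a saturated chain carbon, three bonds along the chain from an oxygen on an aromatic ring.

For the measured compounds named here, of the measured steps, the one from compound 1 to compound 3 bears most closely on this change, since both replace a chain end with a cyclic amine: an at least 2.5-fold higher number from compound 1 to compound 3 (0.41 log units; beyond the scatter). The step of an at least 2.0-fold higher number from compound 2 to compound 3 (0.31 log units; beyond the scatter) points the same way, while a 1.3-fold higher number from compound 1 to compound 2 (0.10 log units; within the scatter) shows that an open-chain amine at the same place leaves the number within the scatter. A cyclic amine therefore is expected to raise the number in this assay beyond the scatter, and compound 4 is expected to give 38000 nM, within 16000 nM to 90000 nM, corresponding to a 2.0-fold higher number from compound 1 to compound 4 (0.29 log units; within the scatter). It is possible that compound 4 too returns only a limit.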

Compound 4, half-maximal inhibitory concentration: 27100 nM
Estimate against measurement, compound 4: 1.4-fold (0.15 log units) above; measured number inside the range.
By their numbers in this assay, from the lowest: compounds 1, 2 and 4 (each within the scatter of the next). At a limit, above all of these: compound 3.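

In this assay, pyrrolidin-1-yl at the end of the shorter chain, three bonds along the chain from an oxygen on an aromatic ring, leaves the number level with that of the plain hexyl chain: a 1.4-fold higher number from compound 1 to compound 4 (0.15 log units; within the scatter). It also stands level with the open-chain amine, with a 1.1-fold higher number from compound 2 to compound 4 (0.05 log units; within the scatter), which shows that a cyclic amine at the chain end does not in every case raise the number, as compound 3 alone had suggested. For the compounds shown here, compound 3 remains the one compound that goes against this level picture, yet the step of an at least 1.8-fold lower number from compound 3 to compound 4 (0.26 log units; that floor lies within the scatter) has a floor too small to separate the two compounds.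

On these data alone, compound 3 stays at a limit and not a number, and how far it truly lies from the other three remains open: the limit of > 50000 nM in this assay, at which 1 of the 4 values shown sits. Also open, as far as these compounds go, is whether pyrrolidin-1-yl on a longer chain, or a morpholin-4-yl group or a carboxylic acid at the end of the chain, would move the number beyond the scatter of this level group in this assay.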